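The compounds below may be only part of what the source reports. "The series", "measured", "known", "first", "only" and "open" are said of these compounds alone.

Compound 1 `CC(C)N(C)c1ccc2cc(NC(=O)CCc3ccc(C(F)(F)F)cc3)ccc2n1`: 140 nM
Compound 2 `CN(c1ccc2cc(NC(=O)CCc3ccc(C(F)(F)F)cc3)ccc2n1)C1CCCC1`: 350 nM
Compound 3 `CC(C)C(=O)NC1CCN(c2ccc3cc(NC(=O)CCc4ccc(C(F)(F)F)cc4)ccc3n2)C1`: 90 nM

In a functional assay on HEK293 cells for activation of melanin-concentrating hormone receptor 1 (Rattus norvegicus), read by inositol phosphate accumulation (a lower number here means that less compound is needed, a higher number that more compound is needed for the effect), compound 1 gives 140 nM, which places it second highest of the three numbers; compound 3 lies nearest, with a step of a 1.6-fold lower number from compound 1 to compound 3 (0.19 log units; within the scatter), and compound 2 furthest, with a step of a 2.5-fold higher number from compound 1 to compound 2 (0.40 log units; beyond the scatter). Between the other two the step is a 3.9-fold lower number from compound 2 to compound 3 (0.59 log units; beyond the scatter).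

Compound 4 `CN(C)c1ccc2cc(NC(=O)CCc3ccc(C(F)(F)F)cc3)ccc2n1` differs from compound 1 in one place: methyl in place of isopropyl on a nitrogen on an aromatic ring. Among the measured compounds shown here, the only measured step at this same nitrogen is the one from compound 1 to compound 2, where a larger group, cyclopentyl, entered in place of isopropyl and the number rose by a 2.5-fold higher number from compound 1 to compound 2 (0.40 log units; beyond the scatter). Here the change runs the other way, toward a smaller group, and no measured pair shows what a smaller group does at this position. He therefore expects a step of a 1.4-fold higher number from compound 1 to compound 4 (0.15 log units; within the scatter) for compound 4, modest at most and possibly within the scatter, with the direction uncertain. His estimate for compound 4 in this assay is 200 nM, within a range from 70 nM to 600 nM.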

Compound 4, half-maximal effective concentration: 110 nM
Beside the measured number, compound 4's estimate is 1.8-fold (0.26 log units) above it, and the stated range covers the measured number.
By their numbers in this assay, from the lowest: compounds 3, 4 and 1 (each within the scatter of the next); then compound 2.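

In this assay, methyl on this nitrogen in place of isopropyl gives a 1.3-fold lower number from compound 1 to compound 4 (0.10 log units; within the scatter) (a smaller group here therefore leaves the number indistinguishable from that of compound 1, at least for this pair). Cyclopentyl is now the group that sets itself apart at this nitrogen, with a 3.2-fold lower number from compound 2 to compound 4 (0.50 log units; beyond the scatter) as a second step beyond the scatter, while dimethylamino in place of 3-((isopropylcarbonyl)amino)pyrrolidin-1-yl gives a 1.2-fold higher number from compound 3 to compound 4 (0.09 log units; within the scatter) and so opens no gap. Nothing measured here explains why these steps fall as they do.

The compounds shown leave open whether an ethyl group on this nitrogen, or a bare amine with no alkyl group on it, would stay with compound 1 and compound 4. They also leave open whether the step with cyclopentyl belongs to a ring as such, which a cyclopropyl or a tert-butyl group on the nitrogen could help to separate.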